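Nitro at the place where bromo once stood

The source may report more compounds than this note shows. Statements on the series, on what has been measured and on what is new or still open speak of the compounds shown alone.

Measured compounds in an ADME assay on MT4 cells (Homo sapiens) for cytotoxicity, read by MTT assay, with a stated time of 4 days; a higher number here means that more compound is tolerated, a lower number that less compound is tolerated:
Compound 1, `O=C(COc1cccc2ccccc12)N/N=C/c1ccccc1Br`, gives 11.4 ug/mL.
Compound 2, `CSc1ccc(/C=N/NC(=O)COc2cccc3ccccc23)cc1`, gives 68.3 ug/mL.
Compound 3, `O=C(COc1cccc2ccccc12)N/N=C/c1ccccc1`, reaches only a limit of the assay, >= 96.6 ug/mL.

Compound 3 thus stands at the top of the measured numbers, at the limit of >= 96.6 ug/mL in this assay, at which 1 of the 3 values shown sits, so its true value is not known. From it, compound 4, `O=C(COc1cccc2ccccc12)N/N=C/c1ccccc1[N+](=O)[O-]`, arises by one change: nitro in place of hydrogen on an aromatic carbon. Going by the values given here, two measured steps touch the same aromatic ring. Replacing the bromo of compound 1 by hydrogen gave an at least 8.4-fold higher number from compound 1 to compound 3 (0.92 log units; beyond the scatter), and exchanging the whole aryl group gave a 6.0-fold higher number from compound 1 to compound 2 (0.78 log units; beyond the scatter), while the shorter move gave only an at least 1.4-fold higher number from compound 2 to compound 3 (0.15 log units; that floor lies within the scatter). A substituent at the place where bromo sat has therefore lowered the number beyond the scatter once, and a nitro group there is expected to act in the same direction, though its size is uncertain. Compound 4 is estimated at 40 ug/mL, within 10 ug/mL to 100 ug/mL, which means an expected step of an at least 2.4-fold lower number from compound 3 to compound 4 (0.38 log units; beyond the scatter).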

Compound 4, half-maximal cytotoxic concentration: 12.2 ug/mL
For compound 4 the middle estimate is 3.3-fold (0.52 log units) above the measured one; the range from low to high includes it.
By their numbers in this assay, from the lowest: compounds 1 and 4 (each within the scatter of the next); then compound 2. At a limit, above all of these: compound 3.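

Compound 3 has only hydrogen at this place on the aromatic ring, and its entry in this assay is a limit of the assay, not a number: the limit of >= 96.6 ug/mL in this assay, at which 1 of the 4 values shown sits. Adding nitro there gives an at least 7.9-fold lower number from compound 3 to compound 4 (0.89 log units; beyond the scatter), so a second kind of substituent at this place lowers the number beyond the scatter, which the earlier compounds had shown for bromo alone. Exchanging the two substituents gives a 1.1-fold higher number from compound 1 to compound 4 (0.03 log units; within the scatter), so nitro and bromo at this place cannot be told apart in this assay.

Going by these compounds, whether this holds for other groups at the same place remains open, and an amine or a carboxylic acid there would test it. Also open, on these data alone, is what nitro would do at the place that methylsulfanyl holds in compound 2.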